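From 1H-benzimidazol-2-yl to 1,3-benzothiazol-2-yl in compound 4

A few compounds are considered here, and "the series" means these few. Any claim that something is new, unique, unknown or untested is made for them only; others in the source may bear on it.

Measured in a functional assay on HL-60 cells (Homo sapiens) for antiproliferative activity, read by MTT assay, with a stated time of 48 h (on this read-out lower numbers stand for stronger inhibition and higher numbers for weaker inhibition), so far:
Compound 1 `CN(C)CCn1c(N)c(-c2nc3ccccc3[nH]2)c2nc(C#N)c(C#N)nc21` gives 2220 nM
Compound 2 `N#Cc1nc2c(-c3nc4ccccc4[nH]3)c(N)n(CCO)c2nc1C#N` gives > 50000 nM
Compound 3 `CN(C)CCCn1c(N)c(-c2nc3ccccc3[nH]2)c2nc(C#N)c(C#N)nc21` gives 870 nM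

Compound 1 has the higher of the two true numbers, with a 2.6-fold lower number from compound 1 to compound 3 (0.41 log units; beyond the scatter) as a modest step. For compound 2 the result > 50000 nM is only a limit of the assay.

Compound 4 `CN(C)CCn1c(N)c(-c2nc3ccccc3s2)c2nc(C#N)c(C#N)nc21` carries 1,3-benzothiazol-2-yl in place of 1H-benzimidazol-2-yl on an aromatic carbon and keeps the 2-(dimethylamino)ethyl group. The measured steps all change that chain: an at least 22-fold higher number from compound 1 to compound 2 (1.35 log units; beyond the scatter) and an at least 57-fold lower number from compound 2 to compound 3 (1.75 log units; beyond the scatter) are large, yet none touches this aromatic carbon. So the estimate stays anchored on compound 1 at 2220 nM in this assay and expects no step beyond the scatter, here a 1.4-fold higher number from compound 1 to compound 4 (0.13 log units; within the scatter) as the expected step. Compound 4 is expected at about 3000 nM (estimated range 700 nM to 13000 nM).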

Compound 4, half-maximal inhibitory concentration: 1670 nM
Beside the measured number, compound 4's estimate is 1.8-fold (0.25 log units) above it; measured number inside the range.
By their numbers in this assay, from the lowest: compounds 3, 4 and 1 (each within the scatter of the next, the first and the last beyond it). At a limit, above all of these: compound 2.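

Among the compounds shown here, the earlier compounds differed only in the chain, so this is the only view of the group on this aromatic carbon: in this assay, 1,3-benzothiazol-2-yl in place of 1H-benzimidazol-2-yl gives a 1.3-fold lower number from compound 1 to compound 4 (0.12 log units; within the scatter). The change removes the hydrogen-bond donor and brings in sulfur, yet this read-out does not separate the two compounds. Nothing shown here explains this result.

As far as these compounds go, whether a phenyl ring or a 1,3-benzoxazol-2-yl group on this carbon would give a similar number remains open. So does whether 1,3-benzothiazol-2-yl would behave alike on the chain of compound 3.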